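The compounds below may be only part of what the source reports. "The series", "measured", "known", "first", "only" and "open" are said of these compounds alone.

In an ADME assay (liver) for metabolic stability, with Liver microsome (Homo sapiens) as the target, using microsomes (on this read-out lower numbers stand for slow clearance and higher numbers for fast clearance), compound 1 `CC[C@@H](Nc1nnc(-c2c[nH]c3ncccc23)o1)c1ccccc1` gives 70 mL.min-1.g-1, compound 2 `CC(C)[C@@H](Nc1nnc(-c2c[nH]c3ncccc23)o1)c1ccccc1` gives 66 mL.min-1.g-1 and compound 3 `c1ccc([C@H](Nc2nnc(-c3c[nH]c4ncccc34)o2)C2CC2)cc1` gives 56 mL.min-1.g-1. Compound 3 stands within the scatter of the other two, with a 1.3-fold lower number from compound 1 to compound 3 (0.10 log units; within the scatter) and a 1.2-fold lower number from compound 2 to compound 3 (0.07 log units; within the scatter). The remaining step, a 1.1-fold lower number from compound 1 to compound 2 (0.03 log units; within the scatter), is equally small. Compound 4 `Fc1ncccc1[C@H](Nc1nnc(-c2c[nH]c3ncccc23)o1)C1CC1` keeps the cyclopropyl and carries 2-fluoropyridin-3-yl in place of phenyl on a saturated chain carbon bound to a nitrogen on an aromatic ring and a saturated ring carbon. All measured steps concern the saturated group, so none of them gives the size of a change to phenyl. A modestly lower number in this assay is expected, but this rests on the structural change alone. The estimated step is a 1.6-fold lower number from compound 3 to compound 4 (0.22 log units; within the scatter). Compound 4 is estimated at 34 mL.min-1.g-1, with an expected range of 15 mL.min-1.g-1 to 70 mL.min-1.g-1.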

Compound 4, intrinsic clearance in microsomes: 21 mL.min-1.g-1
Compound 4: the middle estimate sits 1.6-fold (0.21 log units) above what was measured; the measured number falls inside the stated range.
By their numbers in this assay, from the lowest: compound 4; then compounds 3, 2 and 1 (each within the scatter of the next).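

In this assay 2-fluoropyridin-3-yl in place of phenyl gives a 2.7-fold lower number from compound 3 to compound 4 (0.43 log units; beyond the scatter) and is the only step shown that lies beyond the scatter. This place therefore responds to a change of the aromatic group, whereas the exchanges among ethyl, isopropyl and cyclopropyl all stayed within the scatter. No available measurement bears on the reason for this step.

The compounds shown leave open whether the ring nitrogen or the fluorine carries the step; 2-fluorophenyl and pyridin-3-yl at this place would separate the two. Also open, going by these compounds, is whether the step holds with ethyl or isopropyl in place of cyclopropyl.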